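The source may hold more compounds than are shown below. What is called first, only, known or untested is meant among the compounds shown, and "the series" means these compounds.

In a functional assay on BXPC-3 cells (Homo sapiens) for inhibition, read by MTT assay, with a stated time of 72 h (on this read-out lower numbers stand for stronger inhibition of growth and higher numbers for weaker inhibition of growth), compound 1 `CC(C)(C)c1ccc(CNCCCNS(=O)(=O)c2cc(C(F)(F)F)cc(C(F)(F)F)c2)cc1` gives 1400 nM and compound 2 `O=S(=O)(NCCCNCc1ccc(C(F)(F)F)cc1)c1cc(C(F)(F)F)cc(C(F)(F)F)c1` gives 1700 nM; the two numbers sit within the scatter of each other, as the step of a 1.2-fold higher number from compound 1 to compound 2 (0.08 log units; within the scatter) shows. Compound 3 `O=S(=O)(NCCCNCc1ccc(Br)cc1)c1cc(C(F)(F)F)cc(C(F)(F)F)c1` differs from compound 2 by bromo in place of trifluoromethyl on an aromatic carbon. For the measured compounds named here, no measured step involves a bromo group, so only the small step from compound 1 to compound 2 bears on the change, and it stayed within the scatter. For compound 3 the expected step of no change at the digits printed from compound 2 to compound 3 (within the scatter) is therefore no larger than the scatter, and compound 3 is estimated at 1700 nM in this assay, with a range of 700 nM to 4000 nM.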

Compound 3, concentration for 50% growth inhibition: 1500 nM
Beside the measured number, compound 3's estimate is 1.1-fold (0.05 log units) above it, and the stated range covers the measured number.
By their numbers in this assay, from the lowest: compounds 1, 3 and 2 (each within the scatter of the next).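

In this assay bromo joins tert-butyl and trifluoromethyl on this aromatic carbon, para to a large group, and both a 1.1-fold lower number from compound 2 to compound 3 (0.05 log units; within the scatter) and a 1.1-fold higher number from compound 1 to compound 3 (0.03 log units; within the scatter) leave the number unmoved beyond the usual variation. The single heavy atom of bromo therefore reads the same here as the four heavy atoms of trifluoromethyl, and the assay does not separate the three groups. Nothing measured here accounts for this. Going by these compounds, what an amine or a carboxylic acid on this carbon would do remains open, as does the effect of a longer chain in the shared core.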